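Replacing methyl with 1H-1,2,3-triazol-4-yl in compound 2

The compounds below may be only part of what the source reports. "The series", "measured", "known", "first", "only" and "open" are said of these compounds alone.

In a physicochemical assay for solubility, read by turbidimetry, measured as kinetic solubility, at pH 7.4 (on this read-out lower numbers stand for lower solubility and higher numbers for higher solubility), compound 1 (`COc1ccc(F)cc1N1C(=O)CSC1c1cccc(C(=O)NCCCCc2ccccc2)c1`) gives 10000 nM and compound 2 (`Cc1cccc(N2C(=O)CSC2c2cccc(C(=O)NCCCCc3ccccc3)c2)c1`) gives 10000 nM, so compound 2 stands level with compound 1. Compound 3 (`O=C(NCCCCc1ccccc1)c1cccc(C2SCC(=O)N2c2cccc(-c3c[nH]nn3)c2)c1`) carries 1H-1,2,3-triazol-4-yl in place of methyl on an aromatic carbon, meta to a large group: 1H-1,2,3-triazol-4-yl in place of methyl on an aromatic carbon. Among the compounds with values here, the one measured step bearing on this is no change at the digits printed from compound 1 to compound 2 (within the scatter). That step involves no 1H-1,2,3-triazol-4-yl, so it is only a loose guide. No change beyond the scatter is expected in this assay. The expected change is no change at the digits printed from compound 2 to compound 3 (within the scatter). Compound 3 is estimated at 10000 nM, with a range of 3000 nM to 30000 nM.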

Compound 3, solubility: 20000 nM
Compound 3: the middle estimate sits 2.0-fold (0.30 log units) below what was measured; the measured number falls inside the stated range.
By their numbers in this assay, from the lowest: compounds 1, 2 and 3 (each within the scatter of the next).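

In this assay, 1H-1,2,3-triazol-4-yl in place of methyl on an aromatic carbon, meta to a large group, reads as a 2.0-fold higher number from compound 2 to compound 3 (0.30 log units; within the scatter), so this position accepts a five-membered aromatic ring with 3 hetero atoms without a step beyond the scatter. The wider change on the amide-type nitrogen in a ring reads as a 2.0-fold higher number from compound 1 to compound 3 (0.30 log units; within the scatter), again with no step beyond the scatter. No supporting data bear on why the read-out holds here.

Going by these compounds, whether an amine or a carboxylic acid on this aromatic carbon would give a step beyond the scatter remains open.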